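A few compounds are considered here, and "the series" means these few. Any claim that something is new, unique, unknown or untested is made for them only; others in the source may bear on it.

Measured in a physicochemical assay for lipophilicity; a lower number here means a more polar compound, a higher number a more lipophilic compound:

- compound 1 `CCSc1ccccc1C1=NC(c2ccccc2)CO1`: 4.04
- compound 2 `Clc1ccc(C2=NC(c3ccccc3)CO2)cc1`: 4.48
- compound 3 `FC(F)(F)c1ccccc1-c1ncco1`: 2.15

Compound 1 holds the second highest of these three numbers. Its nearest neighbour is compound 2 at 4.48, higher by more than the usual scatter. Furthest away is compound 3 at 2.15, lower and well beyond the scatter.

The account now turns to compound 4 `CSc1ccccc1C1=NC(c2ccccc2)CO1`, which has not yet been measured in this assay. It differs from compound 1 in one place: hydrogen in place of methyl on a saturated chain carbon bound to a sulfur. In words, this is hydrogen in place of methyl on a saturated chain carbon bound to a sulfur, so ethylsulfanyl becomes methylsulfanyl.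

For the measured compounds named here, no two measured compounds differ in only one place, so the data hold no direct precedent for this change. Neither compound 2 nor compound 3 can size it. The expectation therefore rests on the structural change alone, applied to compound 1 at 4.04: a modest move towards the more polar end of the scale, probably just clear of the scatter.

The expected change is a number 0.44 log units lower from compound 1 to compound 4 (beyond the scatter). For compound 4 the estimated value is 3.6, with an expected range from 3.25 to 3.95.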

Compound 4, partition coefficient: 3.5
Compound 4: middle estimate off by 0.10 log units, on the high side; the measured number falls inside the stated range.
By their numbers in this assay, from the lowest: compound 3; then compound 4; then compound 1; then compound 2.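

For the compounds shown here, compound 1 and compound 4 form the first pair in this set that differs in one place, so the effect of a change at this position can now be read directly rather than inferred. In this assay, hydrogen in place of methyl on a saturated chain carbon bound to a sulfur, which turns ethylsulfanyl into methylsulfanyl, gives a number 0.54 log units lower from compound 1 to compound 4 (beyond the scatter), a modest step that shows the end of this chain registers in the read-out even though only one carbon leaves and the rest of the structure stays the same. The data offer nothing that accounts for the size of this step, so it stands as an observation without an explanation.

As far as these compounds go, with a single pair, it remains open whether the number would keep climbing with a longer chain such as propyl or butyl on the sulfur, or how a hydroxyl or an amine on that chain would compare with the methyl. Going by these compounds alone, it is equally open whether ethylsulfanyl to methylsulfanyl would give a step of similar size on a core other than the one shared by compound 1 and compound 4.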